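Replacing the dichlorophenyl group of compound 2

A few compounds are considered here, and "the series" means these few. Any claim that something is new, unique, unknown or untested is made for them only; others in the source may bear on it.

Compound 1 `Cc1cc(C#N)cc(C)c1Oc1ccnc(S(=O)(=O)CC(=O)Nc2ccc(Cl)cc2Cl)n1` – 10400 nM
Compound 2 `Cc1cc(C#N)cc(C)c1Oc1ccnc(S(=O)(=O)CC(=O)Nc2ccc(Cl)c(Cl)c2)n1` – 11700 nM

Going by the values given here, in an ADME assay on MT4 cells (Homo sapiens) for cytotoxicity, read by MTT assay, with a stated time of 4 days (a lower number here means that less compound is tolerated, a higher number that more compound is tolerated), compound 2 stands within the scatter of compound 1, the only other compound measured. Compound 3 `Cc1cc(C#N)cc(C)c1Oc1ccnc(S(=O)(=O)CC(=O)Nc2ccc(C#N)cc2F)n1` has 4-cyano-2-fluorophenyl in place of 3,4-dichlorophenyl on an amide-type nitrogen and is still unmeasured. Among the compounds with values here, only one measured step bears on this change, a 1.1-fold higher number from compound 1 to compound 2 (0.05 log units; within the scatter), and it exchanges one dichlorophenyl group for another. Within the data shown here, no measured compound carries the nitrile or the fluorine, so the guidance is thin. The expected change is a 1.2-fold lower number from compound 2 to compound 3 (0.07 log units; within the scatter), with no step beyond the scatter anticipated. Compound 3 is estimated at 10000 nM, within an expected range of 4000 nM to 25000 nM here.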

Compound 3, half-maximal cytotoxic concentration: > 268000 nM
Compound 3 ended at the assay's limit; the forecaster's own chance of this, stated with the estimate: 15%; middle value at least 26-fold (1.42 log units) from the limit.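

In this assay, the group on the amide-type nitrogen proved to matter: one dichlorophenyl group in place of the other had left the numbers within the scatter, whereas 4-cyano-2-fluorophenyl brought an at least 22-fold higher number from compound 2 to compound 3 (1.35 log units; beyond the scatter) and an at least 25-fold higher number from compound 1 to compound 3 (1.41 log units; beyond the scatter). Compound 3 is recorded only as a limit of the assay, so the full size of both steps is unknown: the limit of > 268000 nM in this assay, at which 1 of the 3 values shown sits.

The nitrile, the fluorine and the loss of both chlorines arrive together, so the compounds shown leave open which of them accounts for the step. From the compounds shown here alone, how a 4-cyanophenyl or a 2-fluorophenyl group alone would read at this place also remains open.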